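Fluoro for Nitro on a Benzothiazole Enaminone Series

This account rests on a few compounds, and the source may have more. Where it says the series, first, only, none or still open, it means among the compounds named here.

Compound 1 `COc1cc(OC)c2sc(-c3ccc(N/C=C\C(=O)c4ccc(OC)c([N+](=O)[O-])c4)c(C)c3)nc2c1`: 10800 nM
Compound 2 `COc1ccc(C(=O)/C=C\Nc2ccc(-c3nc4cc(OC)c(OC)c(OC)c4s3)cc2)cc1[N+](=O)[O-]`: 17100 nM
Compound 3 `COc1cc(OC)c2sc(-c3ccc(N/C=C\C(=O)c4ccc(OC)c(F)c4)c(C)c3)nc2c1`: 13300 nM

Of the compounds shown here, three have been tested in a functional assay on MDA-MB-231 cells (Homo sapiens) for antiproliferative activity, read by sulforhodamine B assay, with a stated time of 48 h; a lower number here means a stronger inhibitor, a higher number a weaker inhibitor. In this assay compound 1 gives 10800 nM, compound 3 gives 13300 nM and compound 2 gives 17100 nM. All three numbers lie within the scatter of one another, so no ordering among them can be claimed.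

Compound 3 arises from compound 1 by one change, (fluoro in place of nitro on an aromatic carbon), and the step is a 1.2-fold higher number from compound 1 to compound 3 (0.09 log units; within the scatter). The difference between the core of compound 1 and the core of compound 2 is not broken down here.

Compound 4 `COc1ccc(C(=O)/C=C\Nc2ccc(-c3nc4cc(OC)c(OC)c(OC)c4s3)cc2)cc1F` is not yet measured. It arises from compound 2 by the same change, (fluoro in place of nitro on an aromatic carbon), placed in the same surroundings as in the earlier pair. Going by the values given here, the step in this assay from compound 2 to compound 4 is therefore expected to be a 1.2-fold higher number from compound 2 to compound 4 (0.07 log units; within the scatter), resting on the one measured example, which was a 1.2-fold higher number from compound 1 to compound 3 (0.09 log units; within the scatter). Compound 4 is thus estimated at 20000 nM, with a likely range from 9000 nM to 45000 nM.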

Compound 4, half-maximal inhibitory concentration: 16500 nM
Compound 4: middle estimate off by 1.2-fold (0.08 log units), on the high side; the range from low to high includes it.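

In this assay, fluoro in place of nitro on an aromatic carbon gives a 1.0-fold lower number from compound 2 to compound 4 (0.02 log units; within the scatter), so on this second core the change again leaves the number within the scatter. The two steps do not differ from each other beyond what repeated measurement allows: the same change on two cores in this assay, a 1.2-fold higher number (0.09 log units; within the scatter) from compound 1 to compound 3 and a 1.0-fold lower number (0.02 log units; within the scatter) from compound 2 to compound 4, 1.3-fold (0.11 log units) apart, within the scatter of two such steps. Going by these compounds alone, this shows that, on these two cores, the change from 4-methoxy-3-nitrophenyl to 3-fluoro-4-methoxyphenyl has the same outcome, with no step that can be told from the scatter, but it rests on two pairs only and does not show that either group is better, nor that a step of real size would carry over from one core to the other.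

The compounds shown leave open whether another group at this place, such as an amine, a nitrile or a carboxylic acid, would move the number beyond the scatter. They also leave open whether the change would give the same outcome on a core carrying a longer chain in place of a methoxy group.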